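This account rests on a few compounds, and the source may have more. Where it says the series, first, only, none or still open, it means among the compounds named here.

Among the compounds with values here, compound 1, `CC(C)CSc1nc(N)nc2c1ncn2/C=C1/CC1(CO)CO`, is the one compound in this set with a number rather than a limit: in an ADME assay on CCRF-HSB-2 cells (Homo sapiens) for cytotoxicity, with a stated time of 7 days (a higher number here means that more compound is tolerated, a lower number that less compound is tolerated), compound 1 gives 60000 nM. Compound 2, `Nc1nc(NCc2ccccc2)c2ncn(/C=C3/CC3(CO)CO)c2n1`, returns only a limit of the assay in this assay, > 20000 nM. Compound 3, `Nc1nc(NC2CC2)c2ncn(/C=C3/CC3(CO)CO)c2n1`, likewise reaches only a limit of the assay in this assay, > 20000 nM. The steps a step that the limit leaves unreadable from compound 1 to compound 2 and a step that the limit leaves unreadable from compound 1 to compound 3 therefore give no readable size, and the step that the two limits leave unreadable from compound 2 to compound 3 is equally unreadable, a point summed up by the limit of > 20000 nM in this assay, at which 2 of the 3 values shown sit.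

The unmeasured compound 4, `CC(C)CNc1nc(N)nc2c1ncn2/C=C1/CC1(CO)CO`, differs from compound 1 in a single place: isobutylamino in place of isobutylsulfanyl on an aromatic carbon. Within the data shown here, none of the measured steps changes the isobutyl chain while keeping it; the two that replace the isobutylsulfanyl group with an amine end at a limit, so they fix no size or direction for this change. Given that every compound here is tolerated at high concentration, compound 4 is expected to remain in the same region, with an estimated step of no change at the digits printed from compound 1 to compound 4 (within the scatter). Compound 4 is thus estimated at 60000 nM, within 20000 nM to 200000 nM.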

Compound 4, half-maximal cytotoxic concentration: > 20000 nM
Compound 4 ended at the assay's limit; the forecaster's own chance of this, stated with the estimate: 40%; the middle value is on the limit's open side.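

Compound 4 returns only a limit of the assay, so no new step can be read between it and compound 1, compound 2 or compound 3: the limit of > 20000 nM in this assay, at which 3 of the 4 values shown sit. From the compounds shown here alone, whether compound 2, compound 3 and compound 4 differ from one another or from compound 1 in this assay stays open.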